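The source may report more compounds than this note shows. Statements on the series, on what has been measured and on what is new or still open speak of the compounds shown alone.

For the measured compounds named here, in an ADME assay on microsomes from liver (Mus musculus) for metabolic stability, with a stated time of 10 min (a higher number here means that more of the compound is left, a lower number that less of the compound is left), compound 1 (`O=C(O)C12CCC(C(=O)N3CC[C@](c4ccc(C(F)(C(F)(F)F)C(F)(F)F)cc4)(S(=O)(=O)c4ccc(F)cc4)C3)(CC1)CC2`) gives 73%, and this is the only number so far. Compound 2 (`O=C(N1CC[C@](c2ccc(C(F)(C(F)(F)F)C(F)(F)F)cc2)(S(=O)(=O)c2ccc(F)cc2)C1)C12CCC(C(=O)O)(CC1)OC2`) has the entry "not determined" (no result reported). Going by the values given here, compound 3 (`COC(=O)[C@H]1CC[C@H](C(=O)N2CC[C@](c3ccc(C(F)(C(F)(F)F)C(F)(F)F)cc3)(S(=O)(=O)c3ccc(F)cc3)C2)CC1`) also has the entry "not determined" (no result reported), so it has no place on the scale, and compound 2 is the one other compound in that position.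

The next compound, compound 4 (`O=C(C1CCS(=O)(=O)CC1)N1CC[C@](c2ccc(C(F)(C(F)(F)F)C(F)(F)F)cc2)(S(=O)(=O)c2ccc(F)cc2)C1`), departs from compound 3 in a single place: 1,1-dioxothian-4-yl in place of 4-(methoxycarbonyl)cyclohexyl on a carbonyl carbon. The 1,1-dioxothian-4-yl takes the place of the 4-(methoxycarbonyl)cyclohexyl on a carbonyl carbon, and the rest of the structure stays the same.

Among the compounds with values here, no pair of measured compounds shows what a change at this place does to the read-out, and compound 3 offers no starting number. Any step in this assay from compound 3 to compound 4 therefore remains a matter of expectation, and none beyond the scatter is expected, in either direction. Within the data shown here, the only anchor is compound 1 at 73%, which shares the core of compound 4, so the estimate is set close to that number and given a wide range. For compound 4, the expected value in this assay is 72%, with an estimated range from 50% to 92%.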

Compound 4, percent of the compound remaining: 96%
The estimate for compound 4 lay 24 percentage points below the measured number, and the stated range ends below it.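

In this assay, the group on the carbonyl carbon now has its first readable step: a number 23 percentage points higher from compound 1 to compound 4 (beyond the scatter). This step shows that the shared core can carry 1,1-dioxothian-4-yl at this place, a single six-membered ring with one hetero atom, and give a higher reading than with the group of compound 1, which has two six-membered rings of carbon only. Any step from compound 2 or compound 3 cannot be read, and nothing available explains the rise in the reading.

This one step exchanges the whole group at once, so the compounds shown do not separate the part played by the sulfur-containing ring from that of the carboxylic acid on compound 1. As far as these compounds go, how an open-chain sulfone, a piperidine ring or a simple amine on the same carbonyl carbon would read in this assay remains open.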